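Exchanging an aryl group on a dimethoxyphenyl-bearing scaffold

The source may report more compounds than this note shows. Statements on the series, on what has been measured and on what is new or still open speak of the compounds shown alone.

Compound 1 `COc1ccc(C=C(C(=O)/C=C/c2cccc(OC)c2OC)C(=O)/C=C/c2cccc(OC)c2OC)cc1OC`: 410 nM
Compound 2 `COc1cccc(/C=C/C(=O)C(=Cc2cc(OC)c(OC)c(OC)c2)C(=O)/C=C/c2cccc(OC)c2OC)c1OC`: 650 nM
Compound 3 `COc1cccc(C=C(C(=O)/C=C/c2cccc(OC)c2OC)C(=O)/C=C/c2cccc(OC)c2OC)c1OC`: 590 nM

In a functional assay on SW480 cells (Homo sapiens) for antiproliferative activity, read by sulforhodamine B assay, with a stated time of 48 h (a higher number here means a weaker inhibitor, a lower number a stronger inhibitor), compound 3 gives 590 nM, which lies within the scatter of both other compounds. The two steps that reach it are a 1.4-fold higher number from compound 1 to compound 3 (0.16 log units; within the scatter) and a 1.1-fold lower number from compound 2 to compound 3 (0.04 log units; within the scatter).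

Compound 4 `COc1cccc(/C=C/C(=O)C(=Cc2ccc(O)c(F)c2)C(=O)/C=C/c2cccc(OC)c2OC)c1OC` keeps the rest of compound 3 and differs at one place: 3-fluoro-4-hydroxyphenyl in place of 2,3-dimethoxyphenyl on a double-bonded chain carbon bound to a double-bonded chain carbon.

Those two steps exchange the group at this same place, and the remaining step, a 1.6-fold higher number from compound 1 to compound 2 (0.20 log units; within the scatter), is methoxy in place of hydrogen on an aromatic carbon. All three stay within the scatter. However, the group at this place carries only methoxy substituents in the measured compounds, so no measurement tests a fluoro or hydroxy group there. On this evidence, no step beyond the scatter is expected in this assay, and no direction is clearly favoured. The expected step is a 1.2-fold lower number from compound 3 to compound 4 (0.07 log units; within the scatter), and the range is kept wide for the untested group.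

For compound 4 the estimated value is 500 nM, with an expected range from 170 nM to 1400 nM.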

Compound 4, half-maximal inhibitory concentration: 330 nM
Beside the measured number, compound 4's estimate is 1.5-fold (0.18 log units) above it; measured number inside the range.
By their numbers in this assay, from the lowest: compounds 4, 1, 3 and 2 (each within the scatter of the next).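

In this assay, exchanging the methoxy-only aryl groups on a double-bonded chain carbon bound to a double-bonded chain carbon for 3-fluoro-4-hydroxyphenyl gives steps that all stay within the scatter (a 1.8-fold lower number from compound 3 to compound 4 (0.25 log units; within the scatter); a 2.0-fold lower number from compound 2 to compound 4 (0.29 log units; within the scatter); a 1.2-fold lower number from compound 1 to compound 4 (0.09 log units; within the scatter)). The earlier compounds shown here showed this place only with methoxy substituents, whereas compound 4 shows that a group carrying fluorine and a hydrogen-bond donor, and no methoxy at all, can stand there without a step beyond the scatter from any of the three. Nothing available here accounts for these numbers.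

The compounds shown leave open what the fluoro and hydroxy groups each contribute, as they enter together and a phenyl group carrying only one of them does not appear among these compounds. They also leave open whether a group of a different kind at this place, such as an amine or a carboxylic acid, would produce a step beyond the scatter.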